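A few compounds are considered here, and "the series" means these few. Any claim that something is new, unique, unknown or untested is made for them only; others in the source may bear on it.

Working notes on the series. Three compounds share the core of compound 2, `CC(=O)NC[C@H]1CN(c2ccc(OC[C@@H](O)CNc3ccccn3)c(F)c2)C(=O)O1`, and differ in the group carried on the saturated chain carbon bound to an oxygen on an aromatic ring. In a physicochemical assay for lipophilicity, read by HPLC (on this read-out higher numbers stand for higher lipophilicity and lower numbers for lower lipophilicity), compound 2 gives 1.37, the highest of the three numbers. Compound 1, `COc1ccc(NC[C@H](O)COc2ccc(N3C[C@H](CNC(C)=O)OC3=O)cc2F)cc1`, gives 0.95 in this assay, and the step of a number 0.42 log units higher from compound 1 to compound 2 (beyond the scatter). Compound 3, `CC(=O)NC[C@H]1CN(c2ccc(OC[C@H](O)CNc3cccnc3)c(F)c2)C(=O)O1`, gives -0.18 in this assay, and the step of a number 1.55 log units lower from compound 2 to compound 3 (beyond the scatter). Both measured steps therefore sit at the amine substituent, and the second shows that a change there can move the number a long way.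

Compound 4, `CC(=O)NC[C@H]1CN(c2ccc(OC[C@H](O)CNCCC(C)C)c(F)c2)C(=O)O1`, is not yet measured in this assay. It differs from compound 2 as follows: 1-hydroxy-2-(isopentylamino)ethyl in place of 1-hydroxy-2-((pyridin-2-yl)amino)ethyl on a saturated chain carbon bound to an oxygen on an aromatic ring. Among the compounds with values here, no measured step exchanges a ring for an open chain at this position, so neither step maps the change directly; the step from compound 2 to compound 3 only indicates that this position is sensitive beyond the scatter. A modest move downward from compound 2 is expected, with a wide margin on either side, given as a number 0.77 log units lower from compound 2 to compound 4 (beyond the scatter). The value of compound 4 in this assay is estimated at 0.6, within a range of -0.3 to 1.4.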

Compound 4, partition coefficient: 1.19
Compound 4: the middle estimate sits 0.59 log units below what was measured; the range from low to high includes it.
By their numbers in this assay, from the lowest: compound 3; then compounds 1, 4 and 2 (each within the scatter of the next, the first and the last beyond it).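

In this assay, isopentyl in place of the pyridin-2-yl group gives a number 0.18 log units lower from compound 2 to compound 4 (within the scatter), so at this position an open chain and this aromatic ring cannot be told apart, and a ring is not needed for a number at the level of compound 2. Set against compound 3, the same chain gives a number 1.37 log units higher from compound 3 to compound 4 (beyond the scatter); the large earlier step is therefore not a general result of moving away from pyridin-2-yl on the amine nitrogen, and among the four compounds the low number belongs to compound 3 alone, at -0.18. No measured information is available to explain why compound 3 stands apart from the others.

The compounds shown leave open whether a pyridin-4-yl group on the amine nitrogen would stand with compound 3 or with compound 2, which would show whether the low number is peculiar to pyridin-3-yl. They also leave open whether the level of compound 4 holds for other saturated groups at this place, such as a shorter ethyl chain, an unbranched pentyl chain or a cyclohexyl ring.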